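Extending the carbamate chain in a selenocyanate series

The compounds below may be only part of what the source reports. "The series", "measured", "known", "first", "only" and "open" are said of these compounds alone.

Three selenium-bearing carbamates were examined in a functional assay on CCRF-CEM cells (Homo sapiens) for cytotoxicity, read by MTT assay, with a stated time of 72 h; a lower number here means that less compound is tolerated, a higher number that more compound is tolerated. Compound 1 `N#C[Se]c1ccc(NC(=O)Oc2ccc(F)cc2)cc1` gives 71100 nM in this assay. Compound 2 `CCCOC(=O)Nc1ccc([Se]C#N)cc1` gives 68800 nM in this assay. Compound 3 `CCCCOC(=O)Nc1ccc([Se][Se]c2ccc(NC(=O)OCCCC)cc2)cc1` gives 72300 nM in this assay. Compound 2 stands alongside the other two: its gap to compound 1 and its gap to compound 3 both fall within the usual scatter of this measurement, so the three numbers cannot be told apart.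

Compound 4 `CCCCOC(=O)Nc1ccc([Se]C#N)cc1` is not yet measured. It differs from compound 2 in one place: methyl in place of hydrogen on a saturated chain carbon, three bonds along the chain from an oxygen next to a carbonyl group. Seen one bond further out, the same change reads propyl to butyl on the carbamate chain.

Since three quite different carbamate substituents in this set all land in the same band, a single added methyl on the chain is expected to move the number little, if at all, and the step of a 1.0-fold higher number from compound 2 to compound 4 (0.01 log units; within the scatter) is estimated to lie within the scatter, with no direction favoured. Compound 4 is therefore expected to give about 70000 nM in this assay, within a range from 35000 nM to 140000 nM.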

Compound 4, concentration lethal to 50% of the cells: 63500 nM
Estimate against measurement, compound 4: 1.1-fold (0.04 log units) above; low and high end bracket the measured number.
By their numbers in this assay, from the lowest: compounds 4, 2, 1 and 3 (each within the scatter of the next).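

Among these compounds, compound 2 and compound 4 form the first pair in this set that differs in one place, so the carbamate chain can now be read directly. The step from propyl to butyl, a 1.1-fold lower number from compound 2 to compound 4 (0.03 log units; within the scatter), in this assay shows that methyl in place of hydrogen at this position, three bonds along the chain from an oxygen next to a carbonyl group, leaves no readable mark on the number. No supporting data accompany this result that could account for it.

This single step cannot show whether the chain stays as undemanding with a longer chain such as hexyl, or with an amine or a carboxylic acid on it. It also leaves open whether the same change would remain within the scatter on another cell line.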